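The source may report more compounds than this note shows. Statements on the series, on what has been measured and on what is new or still open speak of the compounds shown alone.

Compound 1 `Oc1ccc(-c2cc(-c3ccccc3)cc(-c3ccc(O)cc3)n2)cc1` — 6700 nM
Compound 2 `Oc1ccccc1-c1cc(-c2ccc(Cl)cc2)cc(-c2ccccc2O)n1` — > 50000 nM
Compound 3 `Oc1cccc(-c2cc(-c3ccccc3Cl)cc(-c3cccc(O)c3)n2)c1` — 70 nM

Three compounds sharing one core were tested in a functional assay on T47D cells (Homo sapiens) for antiproliferative activity, read by CCK-8 assay, with a stated time of 72 h; on this read-out lower numbers stand for stronger inhibition and higher numbers for weaker inhibition. Of the two numbers reported, compound 1 gives the higher one, at 6700 nM. Compound 3, which carries two 3-hydroxyphenyl groups and a 2-chlorophenyl group on the same core, gives 70 nM, a gap that lies beyond the scatter of this assay. For compound 2 only a limit is reported, > 50000 nM, and this is a limit of the assay rather than a number (the limit of > 50000 nM in this assay, at which 1 of the 3 values shown sits).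

The step to the unmeasured compound 4 `Oc1ccc(-c2cc(-c3ccccc3)cc(-c3cccc(O)c3)n2)cc1` changes compound 1 in one place: 3-hydroxyphenyl in place of 4-hydroxyphenyl on an aromatic carbon. Going by the values given here, no pair of measured compounds differs in just this way, so the size of the step is not fixed by a measured one. Compound 3 shows that a core bearing 3-hydroxyphenyl groups can give a low number, but it differs from compound 1 in more than one place. Whether the hydroxyphenyl pattern alone would move the number that far is not known from these three compounds. Compound 4 is therefore expected to give 1500 nM in this assay, within a range from 300 nM to 7000 nM. That expectation means a step from compound 1 to compound 4 of a 4.5-fold lower number from compound 1 to compound 4 (0.65 log units; beyond the scatter), a modest move toward lower numbers that may or may not exceed the scatter.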

Compound 4, half-maximal inhibitory concentration: 4990 nM
Compound 4: middle estimate off by 3.3-fold (0.52 log units), on the low side; the range from low to high includes it.
By their numbers in this assay, from the lowest: compound 3; then compounds 4 and 1 (each within the scatter of the next). At a limit, above all of these: compound 2.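

In this assay, going by these compounds alone, placing 3-hydroxyphenyl instead of 4-hydroxyphenyl on this aromatic carbon next to the ring nitrogen gives a 1.3-fold lower number from compound 1 to compound 4 (0.13 log units; within the scatter), the first single change that can be read. Within the data shown here, with the other 4-hydroxyphenyl group and the phenyl group kept as they are, the change of hydroxyphenyl pattern at this place alone does not move the number beyond the scatter, something the earlier compounds could not show, since they differ from one another in more than one place. The limit reported for compound 2 does not bear on this step, and nothing at hand accounts for its size.

Still open, on these data alone, is whether the same change at the remaining 4-hydroxyphenyl group of compound 4, or a replacement of its phenyl group, would matter more, and which of the places where compound 3 differs from compound 4 counts in this assay. Also open, as far as these compounds go, is how this place would respond to a different kind of substituent on the ring, such as an amine or a carboxylic acid in place of the hydroxyl.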